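Ethyl to Methyl on the Ring Amine Nitrogen

The compounds below may be only part of what the source reports. "The series", "measured", "known", "first", "only" and "open" are said of these compounds alone.

Compound 1, `N#Cc1ccc(Nc2nc(Oc3ccnc4ccccc34)nc(N3CCCCC3)n2)cc1C(F)(F)F`: 94900 nM
Compound 2, `N#Cc1ccc(Nc2nc(Oc3ccnc4ccccc34)nc(N3CCN(c4ncccn4)CC3)n2)cc1C(F)(F)F`: 85200 nM
Compound 3, `CCN1CCN(c2nc(Nc3ccc(C#N)c(C(F)(F)F)c3)nc(Oc3ccnc4ccccc34)n2)CC1`: 86600 nM

In a functional assay on DU-145 cells (Homo sapiens) for cytotoxicity, read by sulforhodamine B assay, with a stated time of 48 h (on this read-out lower numbers stand for stronger inhibition of growth and higher numbers for weaker inhibition of growth), compound 3 stands second highest of the three numbers; its nearest neighbour is compound 2, with a 1.0-fold higher number from compound 2 to compound 3 (0.01 log units; within the scatter), and its furthest is compound 1, with a 1.1-fold lower number from compound 1 to compound 3 (0.04 log units; within the scatter). Compound 4, `CN1CCN(c2nc(Nc3ccc(C#N)c(C(F)(F)F)c3)nc(Oc3ccnc4ccccc34)n2)CC1`, differs from compound 3 by hydrogen in place of methyl on a saturated chain carbon bound to an amine nitrogen in a ring. The measured steps that bear on this change all touch the same group on the shared core: a 1.1-fold lower number from compound 1 to compound 2 (0.05 log units; within the scatter), a 1.1-fold lower number from compound 1 to compound 3 (0.04 log units; within the scatter) and a 1.0-fold higher number from compound 2 to compound 3 (0.01 log units; within the scatter), every one within the scatter. The step to compound 4 is therefore expected to be none beyond the scatter, a 1.0-fold higher number from compound 3 to compound 4 (0.00 log units; within the scatter). Compound 4 is estimated at 87000 nM, within a range from 45000 nM to 170000 nM.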

Compound 4, concentration for 50% growth inhibition: 51200 nM
Compound 4: the middle estimate sits 1.7-fold (0.23 log units) above what was measured; the measured number falls inside the stated range.
By their numbers in this assay, from the lowest: compounds 4, 2, 3 and 1 (each within the scatter of the next).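

In this assay, the change from 4-ethylpiperazin-1-yl to 4-methylpiperazin-1-yl gives the largest step yet seen at this group on the shared core (a 1.7-fold lower number from compound 3 to compound 4 (0.23 log units; within the scatter)), but it still lies within the scatter. The two other new steps also stay within the scatter (a 1.7-fold lower number from compound 2 to compound 4 (0.22 log units; within the scatter); a 1.9-fold lower number from compound 1 to compound 4 (0.27 log units; within the scatter)), so methyl on the ring amine nitrogen does not separate compound 4 from compound 1, compound 2 or compound 3. No measured evidence accounts for these numbers. The compounds shown leave open whether an unsubstituted piperazine, a longer chain or a carboxylic acid on that nitrogen would move the number beyond the scatter.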